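From a sulfur link to a butylamino group

The source may hold more compounds than are shown below. What is called first, only, known or untested is meant among the compounds shown, and "the series" means these compounds.

- compound 1 `CSc1nc(N)nc2c1ncn2/C=C1/CC1(CO)CO` gives > 100000 nM (a limit)
- compound 2 `CC(C)Sc1nc(N)nc2c1ncn2/C=C1/CC1(CO)CO` gives 94000 nM

Among the measured compounds shown here, in an ADME assay on CCRF-HSB-2 cells (Homo sapiens) for cytotoxicity, with a stated time of 7 days (on this read-out lower numbers stand for higher toxicity in this test and higher numbers for lower toxicity in this test), compound 2 gives the only actual number (94000 nM). The entry for compound 1 is a limit of the assay (the limit of > 100000 nM in this assay, at which 1 of the 2 values shown sits). Compound 3 `CCCCNc1nc(N)nc2c1ncn2/C=C1/CC1(CO)CO` carries butylamino in place of isopropylsulfanyl on an aromatic carbon. For the measured compounds named here, the one measured step, an at least 1.0-fold lower number from compound 1 to compound 2 (0.02 log units; that floor lies within the scatter), only swaps methyl for isopropyl on a sulfur, and neither measured compound carries butylamino, so it is a weak guide. The step expected in this assay is therefore a 1.1-fold lower number from compound 2 to compound 3 (0.04 log units; within the scatter), with none beyond the scatter. Compound 3 is estimated at 85000 nM, within an expected range from 35000 nM to 200000 nM.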

Compound 3, half-maximal cytotoxic concentration: > 20000 nM
Compound 3: no number, only a limit; the forecaster's own chance of this, stated with the estimate: 50%; the middle value lies beyond the limit too.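

Among the compounds shown here, compound 3 gives > 20000 nM, which is a limit and not a number, so no step to compound 3 from compound 1 or compound 2 can be read. The compounds shown leave open how butylamino compares with either sulfur-linked group.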